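Extending the Saturated Chain from Compound 3 to Compound 4

The source may hold more compounds than are shown below. What is called first, only, known or untested is meant among the compounds shown, and "the series" means these compounds.

Measured so far in a functional assay on WM164 cells (Homo sapiens) for antiproliferative activity, read by sulforhodamine B assay, with a stated time of 48 h (a higher number here means a weaker inhibitor, a lower number a stronger inhibitor), are these values
- compound 1 `CCCCCCCCCCCCCCCCNC(=O)[C@@H]1CSC(c2ccc(OC)c(OC)c2)N1` at 500 nM
- compound 2 `CCCCCCCCCCCCCCNC(=O)[C@@H]1CSC(c2ccc(NC(C)=O)cc2)N1` at 600 nM
- compound 3 `CCCCCCCCCCCCCCCNC(=O)[C@@H]1CSC(c2ccc(NC(C)=O)cc2)N1` at 1000 nM

All three values lie within the usual scatter of one another, so compound 3 at 1000 nM stands apart from neither compound 1 nor compound 2 on these numbers. Compound 4 `CCCCCCCCCCCCCCCCCNC(=O)[C@@H]1CSC(c2ccc(NC(C)=O)cc2)N1` has not yet been measured in this assay and differs from compound 3 by ethyl in place of hydrogen on a saturated chain carbon, ten or more bonds along the chain from an amide-type nitrogen in the chain: ethyl in place of hydrogen on a saturated chain carbon, ten or more bonds along the chain from an amide-type nitrogen.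

For the measured compounds named here, one measured step bears on this change. It places methyl in place of hydrogen on the same kind of carbon and reads a 1.7-fold higher number from compound 2 to compound 3 (0.22 log units; within the scatter) in size, a step within the scatter. Going by the values given here, compound 1 differs from the others in more than one place and supplies no such step. Ethyl is a larger addition than that methyl, and no measured step covers it. No step beyond the scatter is therefore expected in this assay in either direction. The estimate means no change at the digits printed from compound 3 to compound 4 (within the scatter) as the expected step. Compound 4 is estimated at 1000 nM with an expected range of 400 nM to 2500 nM for its measurement.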

Compound 4, half-maximal inhibitory concentration: 2400 nM
Compound 4: the middle estimate sits 2.4-fold (0.38 log units) below what was measured, and the stated range covers the measured number.
By their numbers in this assay, from the lowest: compounds 1, 2 and 3 (each within the scatter of the next); then compound 4.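

In this assay, lengthening the saturated chain at this place now shows a measurable loss of activity: the methyl addition read a 1.7-fold higher number from compound 2 to compound 3 (0.22 log units; within the scatter), whereas ethyl in place of hydrogen reads a 2.4-fold higher number from compound 3 to compound 4 (0.38 log units; beyond the scatter). Propyl in place of hydrogen reads a 4.0-fold higher number from compound 2 to compound 4 (0.60 log units; beyond the scatter), so compound 4 stands as weaker than both compound 2 and compound 3, while those two remain within the scatter of each other. No supporting evidence bears on why this change has this effect in the compounds shown.

As far as these compounds go, whether a longer chain would raise the number further, and what a carboxylic acid or an amine in place of the added ethyl would do at this place, remains open. From the compounds shown here alone, compound 1, at 500 nM, differs from the others in more than one place, so it also remains open whether the same chain change would have a similar effect on the core of compound 1.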